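Swapping the Amine on the Sulfonyl Group

The source may report more compounds than this note shows. Statements on the series, on what has been measured and on what is new or still open speak of the compounds shown alone.

Measured compounds:
- compound 1, `Cn1nnnc1-c1ccc(NC(=O)C(C)(O)C(F)(F)F)cc1`: 30900 nM
- compound 2, `CC(O)(C(=O)Nc1ccc(Sc2ccccc2)cc1)C(F)(F)F`: the assay gives only a limit, > 30000 nM
- compound 3, `CCN(CC)S(=O)(=O)c1ccc(NC(=O)C(C)(O)C(F)(F)F)cc1`: 810 nM

All three share one core, an amide of a hydroxylated, trifluoromethyl-bearing acid on an aniline, and differ only in the group on the aromatic ring. In an assay on a protein complex (Cavia porcellus) with sulfonylurea receptors; K-ATP channels (Homo sapiens) as the target (on this read-out lower numbers stand for stronger inhibition and higher numbers for weaker inhibition), compound 3 gives the lowest number reported; the nearest reported number belongs to compound 1, and the step of a 38-fold lower number from compound 1 to compound 3 (1.58 log units; beyond the scatter) is large. The value of compound 2 is a limit of the assay (the limit of > 30000 nM in this assay, at which 1 of the 3 values shown sits), so the step of an at least 37-fold lower number from compound 2 to compound 3 (1.56 log units; beyond the scatter) can only be read as a lower bound. Both steps point the same way: the diethylsulfamoyl group is what pulls the number down.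

Compound 4, `CC(O)(C(=O)Nc1ccc(S(=O)(=O)N2CCSCC2)cc1)C(F)(F)F`, keeps this sulfonyl group and changes only the amine on it: thiomorpholin-4-yl in place of diethylamino on a sulfonyl sulfur. For the measured compounds named here, no measured step alters this part of compound 3, so there is no direct precedent; the measured steps concern the whole group on the ring, not the amine on the sulfonyl sulfur. A cyclic amine in place of an open one is a modest change, and the expected step of a 1.1-fold higher number from compound 3 to compound 4 (0.05 log units; within the scatter) lies within the scatter. Compound 4 is therefore estimated at 900 nM in this assay, in a range from 300 nM to 3000 nM.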

Compound 4, half-maximal inhibitory concentration: 4580 nM
Beside the measured number, compound 4's estimate is 5.1-fold (0.71 log units) below it; measured number outside the range, above it.
By their numbers in this assay, from the lowest: compound 3; then compound 4; then compound 1.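

The amine on the sulfonyl sulfur is not a silent part of the molecule: in this assay, thiomorpholin-4-yl in place of diethylamino gives a 5.7-fold higher number from compound 3 to compound 4 (0.75 log units; beyond the scatter). The earlier steps shown here exchanged the whole group on the aromatic ring, so they could not show that the number also responds to a change further out, within the sulfonyl group itself; a sulfonyl group alone does not fix the number, although compound 4 gives 4580 nM and compound 1 gives 30900 nM, which still leaves compound 4 with the lower number. No measurement shown here bears on the reason for this step.

The step changes several things at once, since the entering amine is a ring, is larger by the counted heavy atom and carries a sulfur, and two amines cannot tell these apart. Morpholine, with an oxygen in place of the ring sulfur, piperidine, with a carbon there, and pyrrolidine, an all-carbon ring of a smaller size, would each begin to separate the effect of closing a ring from the effect of the sulfur.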